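From methoxy to pyridin-3-yl on the shared core

The source may hold more compounds than are shown below. What is called first, only, known or untested is meant among the compounds shown, and "the series" means these compounds.

Compound 1 `COC(C)(C)CCOc1cccc(OCc2[nH]c3ccccc3c(=O)c2C)c1`: 2000 nM
Compound 2 `COc1ccc2[nH]c(COc3cccc(OCC4CCOCC4)c3)c(C)c(=O)c2c1`: < 1000 nM

Both compounds were tested in a physicochemical assay for solubility, at pH 6.8; on this read-out lower numbers stand for lower solubility and higher numbers for higher solubility. Compound 1 returns a number there, 2000 nM. Compound 2 returns no number, only the limit of the assay, < 1000 nM.

Compound 3 `Cc1c(COc2cccc(OCC3CCOCC3)c2)[nH]c2ccc(-c3cccnc3)cc2c1=O` is still unmeasured. It matches compound 2 except at one place, with pyridin-3-yl in place of methoxy on an aromatic carbon. Going by the values given here, no measured pair of compounds differing in one place is available to indicate how this assay responds to such a change. The expected step, a step that the limit leaves unreadable from compound 2 to compound 3, is therefore none beyond the scatter, in either direction. The reading may again be only a limit. For compound 3 the estimated value is 700 nM, with an expected range from 200 nM to 1800 nM.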

Compound 3, solubility: < 1000 nM
Compound 3: only a limit was reported; the forecaster's own chance of this, stated with the estimate: 65%; the middle value lies beyond the limit too.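

In this assay compound 2 and compound 3 each return only a limit, so no step from compound 2 to compound 3 can be read: the limit of < 1000 nM in this assay, at which 2 of the 3 values shown sit.

The compounds shown leave open whether pyridin-3-yl in place of methoxy on an aromatic carbon changes the read-out at all, and in which direction.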